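Piperazine acetamides: pyridyl swap from compound 2 to compound 4

The compounds below may be only part of what the source reports. "The series", "measured", "known", "first", "only" and "open" are said of these compounds alone.

Measured so far in an assay on isolated protein for inhibition of long-chain fatty acid transport protein 1 (Mus musculus), read by scintillation counting, with a stated time of 20 min; on this read-out lower numbers stand for stronger inhibition and higher numbers for weaker inhibition:
compound 1 `CC1CCc2sc(NC(=O)CN3CCN(c4ccc(F)cc4)CC3)nc2C1`, 5100 nM
compound 2 `O=C(CN1CCN(c2ccncc2)CC1)Nc1nc2c(s1)CCCC2`, reported only as a limit, > 10000 nM
compound 3 `O=C(CN1CCN(c2ccc(F)cc2)CC1)Nc1nc2ccccc2s1`, reported only as a limit, > 10000 nM

Going by the values given here, compound 1 is the only member with a numbered result in this assay. For compound 2 the assay gives a limit and no number, so compound 2 stands at the limit of > 10000 nM in this assay, at which 2 of the 3 values shown sit, and cannot be ordered against compound 3, whose result is likewise a limit. Among the compounds with values here, no step between measured compounds that differ in one place is available in this set, so the size of any single change is unknown here.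

Compound 4 `O=C(CN1CCN(c2ccccn2)CC1)Nc1nc2c(s1)CCCC2` is the next member, not yet measured. It differs from compound 2 by pyridin-2-yl in place of pyridin-4-yl on an amine nitrogen in a ring, in words: pyridin-2-yl in place of pyridin-4-yl on an amine nitrogen in a ring; both have the same atoms, joined differently. Within the data shown here, with compound 2 sitting at the limit, and no measured step to lean on, the expected change from compound 2 to compound 4 in this assay is none beyond the usual scatter, and the assay is expected most likely to report a limit again, which the step that the limit leaves unreadable from compound 2 to compound 4 expresses. The estimate for compound 4 in this assay is 15000 nM, expected within 4000 nM to 60000 nM.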

Compound 4, half-maximal inhibitory concentration: 4900 nM
Compound 4: middle estimate off by 3.1-fold (0.49 log units), on the high side, within the range that was stated.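

In this assay compound 4, with pyridin-2-yl on the amine nitrogen in the ring, gives 4900 nM, the only numbered result among the pyridyl members shown. Compound 2, with pyridin-4-yl at the same place and the same atoms joined differently, is reported only as a limit, > 10000 nM. Read as a step, the swap gives an at least 2.0-fold lower number from compound 2 to compound 4 (0.30 log units; that floor lies within the scatter), so a shift beyond the usual scatter is not established, although this pair offers the first sign that this place may respond to how the pyridine is joined, and the full size of the step stays unknown: the limit of > 10000 nM in this assay, at which 2 of the 4 values shown sit.

The compounds shown leave open how pyridin-3-yl or an unsubstituted phenyl on the same amine nitrogen would read in this assay, and so whether compound 4 reflects something particular to pyridin-2-yl. They also leave open whether pyridin-2-yl would give a comparable number on the core of compound 1 or the core of compound 3, since no pair shown tests the swap on either core.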